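Trading a Methyl for Hydrogen on a Ring Oxygen

The compounds below may be only part of what the source reports. "The series", "measured", "known", "first", "only" and "open" are said of these compounds alone.

Of the compounds shown here, three have been measured in a functional assay on Caco-2 cells (Homo sapiens), read by fluorescence and BrdU incorporation, with a stated time of 48 h, tested at 25 uM; on this read-out lower numbers stand for a stronger effect and higher numbers for a weaker effect at the one concentration tested. Compound 1 `COc1cc(O)c(C(=O)/C=C/c2ccc(F)cc2)c(OC)c1` gives 30%. Compound 3 `COc1cc(OC)c(C(=O)/C=C/c2ccc(F)cc2)c(OC)c1` gives 13%, and compound 2 `COc1cccc(/C=C/C(=O)c2c(OC)cc(OC)cc2OC)c1` gives 6%. Compound 3 and compound 2 differ in the group on the chain, namely (3-methoxyphenyl in place of 4-fluorophenyl on a double-bonded chain carbon bound to a double-bonded chain carbon); the step of a number 7 percentage points higher from compound 2 to compound 3 (within the scatter), so these two read alike. Compound 3 and compound 1 share that chain group and differ only by hydrogen in place of methyl on an oxygen on an aromatic ring; the step of a number 17 percentage points higher from compound 3 to compound 1 (beyond the scatter).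

Compound 4 `COc1cccc(/C=C/C(=O)c2c(O)cc(OC)cc2OC)c1` has not yet been measured. It differs from compound 2 by hydrogen in place of methyl on an oxygen on an aromatic ring, the same change that turns compound 3 into compound 1, and it occurs twice among these four compounds. The two cores differ as told under (3-methoxyphenyl in place of 4-fluorophenyl on a double-bonded chain carbon bound to a double-bonded chain carbon). Since the earlier step was a number 17 percentage points higher from compound 3 to compound 1 (beyond the scatter), the expectation for compound 4 is a step of similar size, a number 16 percentage points higher from compound 2 to compound 4 (beyond the scatter), resting on that one measured pair alone. On this basis the estimated read-out for compound 4 in this assay is 22%, expected to lie between 8% and 40%.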

Compound 4, a percentage reported as activity, at one concentration (the size of the read-out at that concentration, not a potency): 34%
The estimate for compound 4 lay 12 percentage points below the measured number, and the stated range covers the measured number.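

On the core of compound 2, hydrogen in place of methyl on an oxygen on an aromatic ring again weakens the effect in this assay with a number 28 percentage points higher from compound 2 to compound 4 (beyond the scatter) and the two cores agree in direction and, within the usual scatter, in size: the same change on two cores in this assay, a number 17 percentage points higher (beyond the scatter) from compound 3 to compound 1 and a number 28 percentage points higher (beyond the scatter) from compound 2 to compound 4, 11 percentage points apart, within the scatter of two such steps. Across these two cores, then, the change from methoxy to hydroxy carries over, and the step measured on one core was a fair guide to the step on the other. Within the data shown here, this does not show that the change would behave the same way on other cores, as it rests on only two pairs, each read at a single concentration in one assay, and it does not explain why the effect weakens.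

The compounds shown leave open what an amine or an ethoxy group would do in place of the hydroxy, so it cannot be said whether the weaker effect is specific to the hydroxy. Also open, going by these compounds, is whether a second hydroxy on the same ring would add a further step of similar size.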